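Aryl urea series: phenoxy in place of dimethylamino

The source may hold more compounds than are shown below. What is called first, only, known or untested is meant among the compounds shown, and "the series" means these compounds.

Of the compounds shown here, three on the shared core have been measured in an assay on a protein complex for binding affinity to Neuronal acetylcholine receptor; alpha4/beta2 (Homo sapiens) (a lower number here means a stronger inhibitor, a higher number a weaker inhibitor), and all three sit at the same limit. Compound 1 `CSc1ccc(NC(=O)N[C@@H]2C3CCN(CC3)[C@@H]2Cc2cccnc2)cc1` gives > 10000 nM, which is a limit of the assay and not a number. Compound 2 `O=C(Nc1ccc(F)cc1)N[C@@H]1C2CCN(CC2)[C@@H]1Cc1cccnc1` gives > 10000 nM, again a limit. Compound 3 `CN(C)c1ccc(NC(=O)N[C@@H]2C3CCN(CC3)[C@@H]2Cc2cccnc2)cc1` gives > 10000 nM, also a limit. Consequently the three pairwise steps, a step that the two limits leave unreadable from compound 1 to compound 2, a step that the two limits leave unreadable from compound 1 to compound 3 and a step that the two limits leave unreadable from compound 2 to compound 3, cannot be read in size or direction; the only evidence is the limit of > 10000 nM in this assay, at which 3 of the 3 values shown sit.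

Compound 4 `O=C(Nc1ccc(Oc2ccccc2)cc1)N[C@@H]1C2CCN(CC2)[C@@H]1Cc1cccnc1` differs from compound 3 by phenoxy in place of dimethylamino on an aromatic carbon. Within the data shown here, no measured step bears on this change in a readable way, so nothing among the three measured compounds argues for a move away from the limit. Compound 4 is therefore expected to sit near or at the limit in this assay as well, with the step that the limit leaves unreadable from compound 3 to compound 4 estimated as a formality only. The estimate for compound 4 is 15000 nM, within 3000 nM to 60000 nM.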

Compound 4, inhibition constant: > 10000 nM
Compound 4 ended at the assay's limit; the forecaster's own chance of this, stated with the estimate: 75%; the middle value does not contradict the limit.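

Among these compounds, compound 4 gives > 10000 nM in this assay, a limit and not a number, and no step between compound 4 and compound 1, compound 2 or compound 3 can be read. The compounds shown leave open whether any aromatic substituent on the shared core gives a readable value in this assay.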